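Fluorine for Methyl on the Shared Core

The source may report more compounds than this note shows. Statements on the series, on what has been measured and on what is new or still open speak of the compounds shown alone.

Measured so far:
compound 1 `CSc1ccc(C)cc1NCC1=NCCN1`: 123 nM
compound 2 `Cc1ccc(S(C)(=O)=O)c(NCC2=NCCN2)c1`: 3470 nM

In an assay for binding affinity to Alpha-1B adrenergic receptor (Homo sapiens), read by radioligand binding (a lower number here means a stronger inhibitor, a higher number a weaker inhibitor), compound 1 gives 123 nM, the lowest of the two numbers shown. Compound 2 gives 3470 nM. Among the measured compounds shown here, the one measured step, a 28-fold higher number from compound 1 to compound 2 (1.45 log units; beyond the scatter), came from methylsulfonyl in place of methylsulfanyl on an aromatic carbon.

Compound 3 `CSc1ccc(F)cc1NCC1=NCCN1` differs from compound 1 as follows: fluoro in place of methyl on an aromatic carbon. For the measured compounds named here, no measured step touches this group, so the single measured step offers no direct guide. A change this small is expected to give no step beyond the scatter, a 1.2-fold higher number from compound 1 to compound 3 (0.09 log units; within the scatter). Compound 3 is therefore estimated at 150 nM, within 50 nM to 450 nM.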

Compound 3, inhibition constant: 40.7 nM
Compound 3: middle estimate off by 3.7-fold (0.57 log units), on the high side; the whole stated range lies above it.
By their numbers in this assay, from the lowest: compound 3; then compound 1; then compound 2.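

This aromatic carbon, para to the methylsulfanyl group, is not a silent position: swapping methyl for fluoro, one heavy atom for another, gives a step beyond the scatter (a 3.0-fold lower number from compound 1 to compound 3 (0.48 log units; beyond the scatter)). Among the compounds shown here, the earlier step changed only the sulfur group, so this is the first measured change here, and it moves toward a stronger inhibitor. No measurement shown gives a reason for this shift.

From the compounds shown here alone, whether chloro, methoxy or an amine at this carbon would lower the number further remains open. So does whether fluoro also lowers it when methylsulfonyl replaces methylsulfanyl.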